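Removing the ethyl group from a weakly active aminophenyl thiadiazole

The source may report more compounds than this note shows. Statements on the series, on what has been measured and on what is new or still open speak of the compounds shown alone.

Measured compounds:
compound 1 `CCc1ccc(-c2nn3cc(-c4cccc(N)c4)nc3s2)cc1` gives 6000 nM
compound 2 `C=C(Br)C(=O)Nc1cccc(-c2cn3nc(-c4ccc(CC)cc4)sc3n2)c1` gives 2200 nM
compound 3 `COc1ccc(-c2csc3nc(-c4cccc(N)c4)cn23)cc1` gives 19000 nM

Of the compounds shown here, three have been tested in a functional assay on L1210 cells (Mus musculus) for inhibition, read by cell counting, with a stated time of 2 days; on this read-out lower numbers stand for stronger inhibition and higher numbers for weaker inhibition. Compound 1 sits second highest of the three numbers with 6000 nM; the nearest value is that of compound 2, reached by the step of a 2.7-fold lower number from compound 1 to compound 2 (0.44 log units; beyond the scatter), while compound 3 with 19000 nM lies furthest away, on a different core and with a methoxy group in place of the ethyl.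

Compound 4 `Nc1cccc(-c2cn3nc(-c4ccccc4)sc3n2)c1` has not yet been measured. It differs from compound 1 by hydrogen in place of ethyl on an aromatic carbon. For the measured compounds named here, no measured step concerns this position: the only step in this assay, a 2.7-fold lower number from compound 1 to compound 2 (0.44 log units; beyond the scatter), alters the nitrogen on the other aromatic ring, and compound 3 changes both the core and the para substituent at once, so its number cannot be traced to the ethyl group alone. Nothing in the data therefore points to a shift beyond the scatter in this assay for this change, and compound 4 is expected to give a number close to that of compound 1, perhaps a little higher.

On that basis compound 4 is estimated at 9000 nM, within a range of 3000 nM to 30000 nM, corresponding to an expected step of a 1.5-fold higher number from compound 1 to compound 4 (0.18 log units; within the scatter).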

Compound 4, half-maximal inhibitory concentration: 32000 nM
For compound 4 the middle estimate is 3.6-fold (0.55 log units) below the measured one; measured number outside the range, above it.
By their numbers in this assay, from the lowest: compound 2; then compound 1; then compounds 3 and 4 (each within the scatter of the next).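

In this assay, replacing the ethyl group para to a large group with hydrogen gives a 5.3-fold higher number from compound 1 to compound 4 (0.73 log units; beyond the scatter) and so shows that this position is not indifferent to what it carries. This is the first change in the shown series that can be read at this position on its own: the earlier step altered the nitrogen on the other aromatic ring, while compound 3 differs from compound 1 in more than one place. The ethyl group goes with the lower number in this pair, but no measurement shown here explains the shift.

As far as these compounds go, whether a methyl group would keep part of this difference, or a longer chain such as propyl or butyl would lower the number further, remains open. The compounds shown also do not tell how a hydroxyl group or a carboxylic acid would fare at this position, or whether the (1-bromoethenyl)carbonyl group on the nitrogen would bring a similar step on compound 4.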